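A Sulfoxide Chain End in Place of a Nitrile

This account rests on a few compounds, and the source may have more. Where it says the series, first, only, none or still open, it means among the compounds named here.

Measured so far:
compound 1 `C=CCc1cc(C(C)=O)c(O)cc1OCCCCCCCCC#N`: 50%
compound 2 `CCc1cc(C(C)=O)c(O)cc1OCCCCCC(C)(C)C#N`: 53%

Of the compounds shown here, two have been tested in an assay on isolated protein for binding affinity to leukotriene B4 receptor 1 (Homo sapiens), tested at 1 uM; a higher number here means more inhibition at the concentration tested (going by the name of the read-out), a lower number less inhibition. Compound 1 `C=CCc1cc(C(C)=O)c(O)cc1OCCCCCCCCC#N` gives 50% in this assay, and compound 2 `CCc1cc(C(C)=O)c(O)cc1OCCCCCC(C)(C)C#N` gives 53%. Compound 2 has the higher of the two numbers, but the gap to compound 1 lies within the usual scatter, so the two results cannot be told apart. Among the measured compounds shown here, no pair of measured compounds that differ in only one place is available, so no step size is known.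

Compound 3 `CCc1cc(C(C)=O)c(O)cc1OCCCCCC[S+](C)[O-]` has not been measured. It differs from compound 2 in one place: a group of 4 heavy atoms (2 carbon, 1 oxygen, 1 sulfur; no ring) in place of a group of 5 heavy atoms (4 carbon, 1 nitrogen; no ring), on a saturated chain carbon, five bonds along the chain from an oxygen on an aromatic ring. Without a measured step to lean on, a step in this assay of no more than the scatter is expected, if anything a slight fall. Compound 3 is expected to give 45% in this assay, with a range from 20% to 70%. This amounts to an expected step of a number 8 percentage points lower from compound 2 to compound 3 (within the scatter).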

Compound 3, a percentage reported as inhibition, at one concentration (the size of the read-out at that concentration, not a potency): 50%
Compound 3: the middle estimate sits 5 percentage points below what was measured; the range from low to high includes it.
By their numbers in this assay, from the lowest: compounds 1, 3 and 2 (each within the scatter of the next).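

Among the compounds shown here, the first step that can be read at this position, in this assay, is a number 3 percentage points lower from compound 2 to compound 3 (within the scatter). At this place on the chain, five bonds along from an oxygen on an aromatic ring, the 1-cyano-1-methylethyl group and the sulfoxide end therefore cannot be told apart, so for this pair a chain end without a triple bond reads the same as one with it. Nothing at hand bears on why the two chain ends read alike.

As far as these compounds go, whether other ends, such as an amine or a carboxylic acid, would also stay within the scatter at this place remains open. So does whether the sulfoxide would hold up on a shorter or a longer chain, and how the ethyl group on the shared core compares with an allyl group with the chain kept the same.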